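From isobutylamino to hexylsulfanyl on a shared core

The source may hold more compounds than are shown below. What is called first, only, known or untested is meant among the compounds shown, and "the series" means these compounds.

Compound 3 `CC(C)CNc1nc(N)nc2c1ncn2/C=C1/CC1(CO)CO` offers no number to start from: in an ADME assay on MOLT-3 cells (Homo sapiens) for cytotoxicity, with a stated time of 7 days (a lower number here means that less compound is tolerated, a higher number that more compound is tolerated), compound 3 is recorded as "not determined" (no result reported). Compound 1 `Nc1nc(OCC(F)(F)F)c2ncn(/C=C3/CC3(CO)CO)c2n1` gives > 20000 nM, which is a limit of the assay and not a number. Compound 2 `CCCCCCCCOc1nc(N)nc2c1ncn2/C=C1/CC1(CO)CO` gives > 20000 nM, again a limit. Within the data shown here, the one measured step, a step that the two limits leave unreadable from compound 1 to compound 2, therefore has no size to carry over, and the evidence is simply (the limit of > 20000 nM in this assay, at which 2 of the 3 values shown sit). Compound 4 `CCCCCCSc1nc(N)nc2c1ncn2/C=C1/CC1(CO)CO` has hexylsulfanyl in place of isobutylamino on an aromatic carbon. No clear step is expected in this assay in either direction, so compound 4 should stay close to that limit. For compound 4 the estimated value is 25000 nM, with an expected range from 10000 nM to 50000 nM.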

Compound 4, half-maximal cytotoxic concentration: > 20000 nM
Compound 4: no number, only a limit (the forecaster's own chance of this, stated with the estimate: 70%); the middle value does not contradict the limit.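

Compound 4, like compound 1 and compound 2, gives only a limit of the assay and not a number, so the steps among these three cannot be read. The compounds shown leave open what actual value any of them would have in this assay.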